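Swapping Methoxy for Methyl on the Weakest Compound

The source may report more compounds than this note shows. Statements on the series, on what has been measured and on what is new or still open speak of the compounds shown alone.

A set of three compounds sharing one core was tested in a functional assay on U2OS cells for antagonist activity at C-X-C chemokine receptor type 3 (Homo sapiens), read by beta-arrestin recruitment; on this read-out lower numbers stand for stronger inhibition and higher numbers for weaker inhibition. Compound 1 `COc1ncc(-c2nc(C(F)(F)F)sc2N2CCN(C(=O)Cn3cnc4cccnc43)[C@H](C)C2)cn1` gives 177 nM. Compound 2 `CCOc1ncc(-c2nc(C(F)(F)F)sc2N2CCN(C(=O)Cn3ccc4cnccc43)[C@H](C)C2)cn1` gives 23 nM. Compound 3 `COc1ncc(-c2nc(C(F)(F)F)sc2N2CCN(C(=O)Cn3nc(C)nc3C)[C@H](C)C2)cn1` gives 558 nM, the highest number of the three and so the weakest inhibitor here, with compound 1 nearest to it and compound 2 furthest away. Within the data shown here, the only comparison that changes a single place, a 3.2-fold higher number from compound 1 to compound 3 (0.50 log units; beyond the scatter), concerns the group on the saturated chain carbon bound to the carbonyl carbon.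

Compound 4 `Cc1ncc(-c2nc(C(F)(F)F)sc2N2CCN(C(=O)Cn3nc(C)nc3C)[C@H](C)C2)cn1` differs from compound 3 at another place: methyl in place of methoxy on an aromatic carbon. Among the measured compounds shown here, no measured pair differs only at this place, so the size of this step cannot be read from the data. Compound 2 carries an ethoxy there but also a different group on the chain, and its value cannot be separated into the two changes. With nothing to anchor it, the step of a 1.3-fold higher number from compound 3 to compound 4 (0.10 log units; within the scatter) is expected to be small, in either direction, and may stay within the scatter. Compound 4 is therefore expected to give about 700 nM, between 250 nM and 2000 nM.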

Compound 4, half-maximal inhibitory concentration: 578 nM
Estimate against measurement, compound 4: 1.2-fold (0.08 log units) above; the measured number falls inside the stated range.
By their numbers in this assay, from the lowest: compound 2; then compound 1; then compounds 3 and 4 (each within the scatter of the next).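

In this assay, putting 2-methylpyrimidin-5-yl in place of 2-methoxypyrimidin-5-yl gives a 1.0-fold higher number from compound 3 to compound 4 (0.02 log units; within the scatter) and so leaves the two compounds indistinguishable on this read-out. This is the only pair shown that changes this position alone, and it shows that, with the chain group shared by compound 3 and compound 4, the methoxy group and its one hydrogen-bond acceptor can give way to a methyl group with no change beyond the scatter. No measurement on hand explains this result.

One pair on one background cannot show whether the same swap would read the same with the chain groups of compound 1 or compound 2. The compounds also leave open how an amine, a hydroxyl group or a longer alkoxy chain such as propoxy would behave at this ring carbon.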